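A few compounds are considered here, and "the series" means these few. Any claim that something is new, unique, unknown or untested is made for them only; others in the source may bear on it.

Measured in an ADME assay on MDBK cells (Bos taurus) for cytotoxicity, read by MTT assay, with a stated time of 96 h; on this read-out lower numbers stand for higher toxicity in this test and higher numbers for lower toxicity in this test:
- compound 1, `Fc1ccc(-c2nc3cc(C(F)(F)F)ccc3[nH]2)cc1`: 19000 nM
- compound 2, `Cn1c(-c2ccc([N+](=O)[O-])cc2)nc2cc(C(F)(F)F)ccc21`: > 100000 nM, a limit of the assay
- compound 3, `COc1ccc(-c2nc3cc([N+](=O)[O-])ccc3[nH]2)c(OC)c1`: > 100000 nM, a limit of the assay

Among the measured compounds shown here, compound 1 is the only member of the set with a definite number; in this assay compound 1 gives 19000 nM. The other two readings are limits, not numbers. Compound 2 gives > 100000 nM, which is a limit of the assay. Compound 3 gives > 100000 nM, likewise a limit. For the measured compounds named here, the picture of the series is thus set by the limit of > 100000 nM in this assay, at which 2 of the 3 values shown sit, and no step between measured compounds can be drawn, since no two of them differ in one place only.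

Compound 4, `Oc1ccc(-c2nc3cc(C(F)(F)F)ccc3[nH]2)cc1`, has not yet been measured in this assay. It differs from compound 1 by hydroxy in place of fluoro on an aromatic carbon. Going by the values given here, no measured step of this kind exists in the set, so the expectation rests on compound 1 alone. The exchange is of a single heavy atom for a single heavy atom, and the step of a 1.6-fold higher number from compound 1 to compound 4 (0.20 log units; within the scatter) is expected to be small, if anything towards lower toxicity, and may well stay within the usual scatter. Compound 4 is accordingly expected to give about 30000 nM, within 10000 nM to 100000 nM, with some chance that only a limit is reported.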

Compound 4, half-maximal cytotoxic concentration: 51000 nM
Beside the measured number, compound 4's estimate is 1.7-fold (0.23 log units) below it, and the stated range covers the measured number.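

In this assay, among the compounds shown here, a 2.7-fold higher number from compound 1 to compound 4 (0.43 log units; beyond the scatter) gives the first step that can be read, and it is a modest one, beyond the scatter, towards lower toxicity in this test. It shows that the place on the six-membered aromatic ring of carbon only, para to a large group, is not silent: exchanging fluoro for hydroxy, with the same count of heavy atoms but one hydrogen-bond donor and one hydrogen-bond acceptor entering, is enough to move the reading. Compound 4, like compound 1, still gives a definite number, so this exchange does not carry the reading to the limit that marks the rest of the set: the limit of > 100000 nM in this assay, at which 2 of the 4 values shown sit.

This remains a single pair on a single core, so the data cannot say which feature of the exchange sets the size of the step, or whether the same step would appear with other substituents elsewhere on the core. Also open, as far as these compounds go, is how an amine, a carboxylic acid or a longer alkoxy chain at the same place would read in this assay, and whether any of them would reach a limit rather than a number.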